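Ethynyl in place of phenyl in the nucleoside series

The compounds below may be only part of what the source reports. "The series", "measured", "known", "first", "only" and "open" are said of these compounds alone.

Measured in a functional assay on A549 cells (Homo sapiens), read by MTT assay, with a stated time of 72 h; on this read-out lower numbers stand for stronger inhibition and higher numbers for weaker inhibition:
- compound 1 `C#Cc1cn([C@@H]2O[C@H](CO)[C@@H](O)[C@H]2O)c2ncnc(OC)c12` gives 8160 nM
- compound 2 `CSc1ncnc2c1c(-c1ccoc1)cn2[C@@H]1O[C@H](CO)[C@@H](O)[C@H]1O` gives 280 nM
- compound 3 `CSc1ncnc2c1c(-c1ccccc1)cn2[C@@H]1O[C@H](CO)[C@@H](O)[C@H]1O` gives > 20000 nM (a limit)

Compound 3 stands at > 20000 nM, a limit and not a number. This is the limit of > 20000 nM in this assay, at which 1 of the 3 values shown sits. Compound 4 `C#Cc1cn([C@@H]2O[C@H](CO)[C@@H](O)[C@H]2O)c2ncnc(SC)c12` has ethynyl in place of phenyl on an aromatic carbon. Going by the values given here, one measured step bears on this change, and it is large and beyond the scatter: an at least 71-fold higher number from compound 2 to compound 3 (1.85 log units; beyond the scatter). Losing phenyl should therefore give a large step to a lower number in this assay. Compound 1 also carries ethynyl and gives 8160 nM, but its core differs from that of compound 4. The expected change is an at least 13-fold lower number from compound 3 to compound 4 (1.12 log units; beyond the scatter). For compound 4 the estimated value is 1500 nM, with an expected range of 150 nM to 12000 nM.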

Compound 4, half-maximal inhibitory concentration: 140 nM
Compound 4: middle estimate off by 11-fold (1.03 log units), on the high side, outside the stated range (below it).
By their numbers in this assay, from the lowest: compounds 4 and 2 (each within the scatter of the next); then compound 1. At a limit, above all of these: compound 3.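

In this assay ethynyl on this aromatic carbon gives an at least 140-fold lower number from compound 3 to compound 4 (2.15 log units; beyond the scatter) against phenyl and a 2.0-fold lower number from compound 2 to compound 4 (0.30 log units; within the scatter) against furan-3-yl, so ethynyl and furan-3-yl are not told apart here and only phenyl stands off. The phenyl end of this comparison is a limit for compound 3, not a number: the limit of > 20000 nM in this assay, at which 1 of the 4 values shown sits. With ethynyl fixed, methylsulfanyl in place of methoxy gives a 58-fold lower number from compound 1 to compound 4 (1.77 log units; beyond the scatter) and so ethynyl alone does not secure the low number.

Open, going by these compounds, is whether a longer chain such as propynyl on this carbon keeps the number, and whether an amine in place of methylsulfanyl does.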